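Replacing the 4-fluorophenyl group of compound 1

The source may report more compounds than this note shows. Statements on the series, on what has been measured and on what is new or still open speak of the compounds shown alone.

Measured in a functional assay on HCT-116 cells (Homo sapiens) for cytotoxicity, read by sulforhodamine B assay, with a stated time of 72 h; on this read-out lower numbers stand for stronger inhibition and higher numbers for weaker inhibition:
compound 1 `CCS(=O)(=O)Nc1cc(-c2ccc3ncnc(Nc4ccc(F)cc4)c3c2)cnc1OC`: 3160 nM
compound 2 `CCS(=O)(=O)Nc1cc(-c2ccc3ncnc(Nc4ccc(F)cc4F)c3c2)cnc1OC`: 4010 nM
compound 3 `CCS(=O)(=O)Nc1cc(-c2ccc3ncnc(Nc4ccc(OC(F)(F)F)cc4)c3c2)cnc1OC`: 16600 nM

Compound 1 and compound 2 form the lower pair of this small set and cannot be told apart, with a 1.3-fold higher number from compound 1 to compound 2 (0.10 log units; within the scatter). Compound 3 lies clear of that pair, with a 4.1-fold higher number from compound 2 to compound 3 (0.62 log units; beyond the scatter).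

Compound 4 `CCS(=O)(=O)Nc1cc(-c2ccc3ncnc(Nc4ccc(Cl)c(C(=O)OC)c4)c3c2)cnc1OC` keeps the core of compound 1 and changes one group: 4-chloro-3-(methoxycarbonyl)phenyl in place of 4-fluorophenyl on a nitrogen on an aromatic ring. In words, it carries 4-chloro-3-(methoxycarbonyl)phenyl in place of 4-fluorophenyl on a nitrogen on an aromatic ring.

Two measured steps alter the group on that same nitrogen. Adding a fluoro gave no shift beyond the scatter, with a 1.3-fold higher number from compound 1 to compound 2 (0.10 log units; within the scatter). Replacing the fluoro with trifluoromethoxy gave a modest rise, with a 5.3-fold higher number from compound 1 to compound 3 (0.72 log units; beyond the scatter). Compound 4 also loses that fluoro, and this replacement is the closer guide. Among the compounds with values here, no measured compound carries a chloro or a methoxycarbonyl group, so the guidance is loose.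

In this assay a modest move towards a higher number is therefore expected, namely a 2.5-fold higher number from compound 1 to compound 4 (0.40 log units; beyond the scatter). Compound 4 is estimated at 8000 nM, with an expected range from 2500 nM to 25000 nM.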

Compound 4, half-maximal inhibitory concentration: 3130 nM
Compound 4: middle estimate off by 2.6-fold (0.41 log units), on the high side; the measured number falls inside the stated range.
By their numbers in this assay, from the lowest: compounds 4, 1 and 2 (each within the scatter of the next); then compound 3.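

In this assay, the group on the nitrogen can change from 4-fluorophenyl to 4-chloro-3-(methoxycarbonyl)phenyl, which has more heavy atoms and brings in hydrogen-bond acceptors, with no shift beyond the scatter: there is a 1.0-fold lower number from compound 1 to compound 4 (0.00 log units; within the scatter), and the comparison with the 2,4-difluorophenyl compound gives a 1.3-fold lower number from compound 2 to compound 4 (0.11 log units; within the scatter). The rise seen with 4-(trifluoromethoxy)phenyl therefore does not extend to every replacement that removes the fluoro at this place, since exchanging that group for 4-chloro-3-(methoxycarbonyl)phenyl gives a 5.3-fold lower number from compound 3 to compound 4 (0.72 log units; beyond the scatter). Nothing available here accounts for this difference between the two groups, so it stands only as an observation on these four compounds.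

The chloro and the methoxycarbonyl enter together, so the compounds shown leave open what each contributes, and a phenyl carrying only the chloro or only the methoxycarbonyl would separate the two. Also open, from the compounds shown here alone, is how the value would respond if a carboxylic acid or a primary amide took the place of the methoxycarbonyl group on the same phenyl.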